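The source may hold more compounds than are shown below. What is called first, only, known or untested is meant among the compounds shown, and "the series" means these compounds.

Compound 3 `Cc1ccc(CN2C(=O)S/C(=C\c3ccccc3Cl)C2=O)cc1` gives 26% in a functional assay on the whole organism (plasma) with Mus musculus as the target, with a stated time of 15 days, at a dose of 30 mg/kg by the oral route (a higher number here means a stronger effect of the compound at the dose given, a lower number a weaker effect), the second highest of the three numbers measured. Compound 2 `COc1ccc(/C=C2\SC(=O)N(Cc3ccc(C)cc3)C2=O)cc1` gives 58.8% and compound 1 `Cc1ccc(CN2C(=O)S/C(=C\c3ccc([N+](=O)[O-])cc3)C2=O)cc1` gives 7.1%; the gap from compound 3 to each of these two lies beyond the scatter. Compound 4 `Cc1ccc(CN2C(=O)S/C(=C\c3ccc(Cl)cc3)C2=O)cc1` differs from compound 3 only in the aryl group: 4-chlorophenyl in place of 2-chlorophenyl on a double-bonded chain carbon bound to a double-bonded ring carbon. Among the compounds with values here, two measured steps bear on it. The change on the aromatic ring gave a number 51.7 percentage points higher from compound 1 to compound 2 (beyond the scatter), and the exchange of the whole aryl group gave a number 32.8 percentage points lower from compound 2 to compound 3 (beyond the scatter). Both show that the substituent on that ring moves this assay widely, yet neither compares a 2-chlorophenyl with a 4-chlorophenyl. A modest upward step, a number 9 percentage points higher from compound 3 to compound 4 (within the scatter), is therefore expected, and compound 4 is estimated at 35%, with a range from 10% to 60%.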

Compound 4, a percentage reported as activity, at one dose (the size of the read-out at that dose, not a potency): 48%
Compound 4: middle estimate off by 13 percentage points, on the low side; the measured number falls inside the stated range.
By their numbers in this assay, from the lowest: compound 1; then compound 3; then compound 4; then compound 2.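

In this assay, exchanging 2-chlorophenyl for 4-chlorophenyl gives a number 22 percentage points higher from compound 3 to compound 4 (beyond the scatter), so with the same atoms, where the chloro sits on the ring already moves the read-out. On the same aromatic carbon, chloro in place of nitro gives a number 40.9 percentage points higher from compound 1 to compound 4 (beyond the scatter), whereas chloro in place of methoxy gives a number 10.8 percentage points lower from compound 2 to compound 4 (beyond the scatter), which places chloro in order of read-out under methoxy and over nitro in these compounds. No measured evidence accounts for these differences. The compounds shown leave open how an amine or a carboxylic acid would stand on that aromatic carbon. They also leave open whether methoxy and nitro respond to a change of ring place as chloro does.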